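The compounds below may be only part of what the source reports. "The series", "measured", "known", "first", "only" and "open" are said of these compounds alone.

Measured so far:

Compound 1 `CCCCCc1cn([C@H]2C[C@H](O)[C@@H](CO)O2)c(=O)[nH]c1=O`: in a functional assay on Raji cells (Homo sapiens) (a lower number here means a stronger inhibitor, a higher number a weaker inhibitor), compound 1 gives 334 ug/mL.
Compound 2 `CC(C)c1cn([C@H]2C[C@@H]3OP(=O)(O)OC[C@H]3O2)c(=O)[nH]c1=O`: in this assay compound 2 gives > 500 ug/mL, which is a limit of the assay and not a number.
Compound 3 `CCCCc1cn([C@H]2C[C@H](O)[C@@H](CO)O2)c(=O)[nH]c1=O`: in this assay compound 3 gives > 500 ug/mL, also a limit of the assay and not a number.

Compound 2 therefore stands at the limit of > 500 ug/mL in this assay, at which 2 of the 3 values shown sit, so no number is known for it, only that it sits at that limit.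

Compound 4 `CCCCCCCCc1cn([C@H]2C[C@@H]3OP(=O)(O)OC[C@H]3O2)c(=O)[nH]c1=O` differs from compound 2 in one place: octyl in place of isopropyl on an aromatic carbon. Within the data shown here, no measured step covers the change from an isopropyl to an octyl chain. Among the measured compounds shown here, the only measured step, an at least 1.4-fold higher number from compound 1 to compound 3 (0.17 log units; that floor lies within the scatter), shortens a chain by one carbon and lands at the limit, so its size is known only as a floor that lies within the scatter; it points, if anywhere, to a longer chain giving a lower number, but it rests on one pair and compound 3 itself sits at the limit.

For compound 4 a number somewhat below the limit is expected, with a step of an at least 1.6-fold lower number from compound 2 to compound 4 (0.22 log units; that floor lies within the scatter) that may still end at the limit. The estimate for compound 4 is 300 ug/mL, with a range from 80 ug/mL to 1000 ug/mL.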

Compound 4, concentration for 50% inhibition: 165 ug/mL
Compound 4: middle estimate off by 1.8-fold (0.26 log units), on the high side; low and high end bracket the measured number.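

On this aromatic carbon, octyl in place of isopropyl gives in this assay an at least 3.0-fold lower number from compound 2 to compound 4 (0.48 log units; beyond the scatter) and is the first change of chain in the series whose step is shown to lie beyond the scatter. The earlier chain step on this carbon, an at least 1.4-fold higher number from compound 1 to compound 3 (0.17 log units; that floor lies within the scatter), has a floor within the scatter and belongs to a different core, so it did not establish that chain identity at this position can shift the number beyond the scatter. Compound 2 gives > 500 ug/mL, which is a limit of the assay and not a number, and the new step is known only as a floor because of it: the limit of > 500 ug/mL in this assay, at which 2 of the 4 values shown sit.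

Open, on these data alone, are the numbers for chains of intermediate size between isopropyl and octyl on this core, and whether a chain longer than octyl or one ending in an amine or a carboxylic acid would give a lower or a higher number. Also open is whether octyl on the core of compound 1 would give a similar number; no pair shown joins the two cores through a single change.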